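Anilinopurine cinnamamides: swap to benzylamine at the ring nitrogen

This account rests on a few compounds, and the source may have more. Where it says the series, first, only, none or still open, it means among the compounds named here.

Measured so far:
compound 1, `Nc1ccccc1NC(=O)/C=C/c1ccc(Cn2cnc3c(Nc4cccc(Cl)c4)nc(Cl)nc32)cc1`: in a functional assay on HCT-116 cells (Homo sapiens) for antiproliferative activity, read by CCK-8 assay, with a stated time of 72 h, tested at 8 uM (on this read-out lower numbers stand for a weaker effect and higher numbers for a stronger effect at the one concentration tested), compound 1 gives 15.8%
compound 2, `Nc1ccccc1NC(=O)/C=C/c1ccc(Cn2cnc3c(Nc4cccc(OC(F)(F)F)c4)nc(Cl)nc32)cc1`: in this assay compound 2 gives 5.23%

Going by the values given here, compound 2 stands lowest of the two, with a number 10.6 percentage points lower from compound 1 to compound 2 (beyond the scatter) as the only measured step. Compound 3, `Nc1ccccc1NC(=O)/C=C/c1ccc(Cn2cnc3c(NCc4ccccc4)nc(Cl)nc32)cc1`, differs by benzyl in place of 3-(trifluoromethoxy)phenyl on a nitrogen on an aromatic ring. Among the compounds with values here, no measured step covers this change; the single known step is modest and concerns only the substituent on the phenyl. Both measured numbers sit low, so a small change in either direction is expected, likely a number 6.8 percentage points higher from compound 2 to compound 3 (within the scatter). Compound 3 is expected to give 12%, in the range 0% to 30%.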

Compound 3, a percentage reported as inhibition, at one concentration (the size of the read-out at that concentration, not a potency): 17.4%
The estimate for compound 3 lay 5.4 percentage points below the measured number; measured number inside the range.
By their numbers in this assay, from the lowest: compound 2; then compounds 1 and 3 (each within the scatter of the next).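

Benzyl in place of 3-(trifluoromethoxy)phenyl on this nitrogen gives a number 12.2 percentage points higher from compound 2 to compound 3 (beyond the scatter) at the one concentration tested, and benzyl in place of 3-chlorophenyl gives a number 1.6 percentage points higher from compound 1 to compound 3 (within the scatter) at that concentration. The same change therefore reads differently against the two aryl groups, and an aromatic ring bound directly to this nitrogen is not required to keep the level of compound 1. No evidence at hand accounts for either step. Still open, from the compounds shown here alone, is how a substituted benzyl, a longer phenylalkyl chain or a cyclohexylamine at this nitrogen would read.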